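The compounds below may be only part of what the source reports. "The series", "measured", "known", "first", "only" and "open" are said of these compounds alone.

Measured compounds:
compound 1, `C=CCOc1cc(F)cc(C(=O)NNS(=O)(=O)c2ccccc2F)c1`: 803 uL/min
compound 2, `Cc1cc(C(=O)NNS(=O)(=O)c2ccccc2F)cc(-n2cc(F)cn2)c1`: 464 uL/min

In an ADME assay on microsomes from liver (Mus musculus) for metabolic stability, read by HPLC, using NADPH, with a stated time of 60 min, tested at 1 uM, in the presence of a further agent that is not named here (on this read-out higher numbers stand for fast clearance and lower numbers for slow clearance), compound 1 gives 803 uL/min, and in this assay compound 2 gives 464 uL/min. Among the measured compounds shown here, these two numbers lie within the usual scatter of each other, so compound 1 cannot be set apart from compound 2 on the numbers so far; no pair of measured compounds differing in a single place is available, so no measured step can be quoted.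

Compound 3, `O=C(NNS(=O)(=O)c1ccccc1F)c1cc(F)cc(-c2ccccn2)c1`, has not yet been measured in this assay. It derives from compound 1 by a single change: pyridin-2-yl in place of allyloxy on an aromatic carbon. The shared core, the fluoro group and the sulfonyl hydrazide part are kept.

For the measured compounds named here, only two numbers exist to guide an expectation, and neither directly tracks this change. A moderate step toward slower clearance is expected, a 2.0-fold lower number from compound 1 to compound 3 (0.30 log units; within the scatter), partly because compound 2, which also carries an aromatic ring on the core, gives 464 uL/min. For compound 3 the estimate in this assay is 400 uL/min, with a range from 150 uL/min to 900 uL/min, and the measurement will show whether this holds.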

Compound 3, intrinsic clearance in a liver preparation (reported as CLH), per the amount of preparation that the assay uses: 131 uL/min
Compound 3: the middle estimate sits 3.1-fold (0.48 log units) above what was measured; measured number outside the range, below it.
By their numbers in this assay, from the lowest: compound 3; then compounds 2 and 1 (each within the scatter of the next).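

In this assay, among the compounds shown here, placing pyridin-2-yl where allyloxy stood, on an aromatic carbon meta to a fluoro group, gives a 6.1-fold lower number from compound 1 to compound 3 (0.79 log units; beyond the scatter) and so provides the only step here that can be read beyond the scatter. It shows that this position is not indifferent: with the shared core, the fluoro group and the sulfonyl hydrazide part kept, a change at this one place is enough to move the clearance read-out. The data give no measured property that would tie this step to the new aromatic ring, its ring nitrogen or the loss of the allyloxy double bond.

The compounds shown leave open whether the lower number goes with the arrival of the pyridin-2-yl ring or with the departure of allyloxy, a question that a plain phenyl ring or a saturated propoxy chain at this place would help to separate. They also leave open whether the ring nitrogen matters and whether its place in the ring does, as a comparison with pyridin-3-yl or pyridin-4-yl would show.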